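The source may hold more compounds than are shown below. What is called first, only, known or untested is meant among the compounds shown, and "the series" means these compounds.

Three triazenes have been measured in a functional assay on L1210 cells (Mus musculus) for antiproliferative activity; a lower number here means a less potent compound, a higher number a more potent compound, by a factor of ten per unit of this negative logarithm. Compound 2 `CCCCCN(C)/N=N/c1nc[nH]c1C(N)=O` gives 3.58 in this assay, while compound 3 `CCCCCCCCN(C)/N=N/c1nc[nH]c1C(N)=O`, which carries a longer chain on the same core, gives 3. The change between these two, (propyl in place of hydrogen on a saturated chain carbon, five bonds along the chain from an amine nitrogen), produced a number 0.58 log units lower from compound 2 to compound 3 (beyond the scatter). Compound 1 `CN(C)/N=N/c1ccc([N+](=O)[O-])cc1C(N)=O` belongs to a different series; how its core differs from that of compound 2 is not broken down here. In this assay compound 1 gives 3.26, which stands within the scatter of the number for compound 3, and compound 2 gives a higher number than compound 1.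

Compound 4 `CCCCN(C)/N=N/c1ccc([N+](=O)[O-])cc1C(N)=O` has not yet been measured. It differs from compound 1 by propyl in place of hydrogen on a saturated chain carbon bound to an amine nitrogen. Among the measured compounds shown here, this is the same kind of change as the one from compound 2 to compound 3, but not the same: there the propyl entered on a saturated chain carbon five bonds along the chain from an amine nitrogen, whereas here it enters on a saturated chain carbon bound to an amine nitrogen, and the core is another one. For the measured compounds named here, with only one earlier example of a chain extension, and that on another core, the expectation rests on the drop seen in a number 0.58 log units lower from compound 2 to compound 3 (beyond the scatter), softened for the change of place. For compound 4 a step of a number 0.31 log units lower from compound 1 to compound 4 (beyond the scatter) is expected. Compound 4 is therefore estimated at 2.95, with a plausible range from 2.4 to 3.5.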

Compound 4, logarithm of the reciprocal of the active concentration, log(1/C): 3.08
Compound 4: the middle estimate sits 0.13 log units below what was measured, and the stated range covers the measured number.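

In this assay propyl in place of hydrogen on the core of compound 1 gives a number 0.18 log units lower from compound 1 to compound 4 (within the scatter) and so, on this core, cannot be told from no change at all. Set beside the earlier step on the other core, the new step cannot be told apart from it either: the same change on two cores in this assay, a number 0.58 log units lower (beyond the scatter) from compound 2 to compound 3 and a number 0.18 log units lower (within the scatter) from compound 1 to compound 4, 0.40 log units apart, within the scatter of two such steps. This fits a change that carries from one core to the other, but it does not show that the step has one size, since each core offers a single pair, only the earlier step lies beyond the scatter, and the propyl enters at a different place in each: on a saturated chain carbon bound to an amine nitrogen in compound 4, and five bonds along the chain from an amine nitrogen in compound 3.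

The compounds shown leave open whether a longer chain than butyl on the core of compound 1 would give a step beyond the scatter, and whether methyl to butyl on the core of compound 2 would match the step seen here. They also leave open what a hydroxyl group, a carboxylic acid or an amine at the end of the chain would do on either core.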